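This account rests on a few compounds, and the source may have more. Where it says the series, first, only, none or still open, it means among the compounds named here.

Compound 1, `O=C(Nc1nc2ccccc2s1)c1cn(-c2ccccc2)nc1-c1ccccc1`, is the reference point of this small series: in a functional assay on HT-29 cells (Homo sapiens) for cytotoxicity, read by MTT assay, with a stated time of 72 h (on this read-out higher numbers stand for weaker inhibition and lower numbers for stronger inhibition), compound 1 gives 16800 nM. Compound 2, `O=C(Nc1nc2ccc(Cl)cc2s1)c1cn(-c2ccccc2)nc1-c1ccccc1`, carries a chloro on the bicyclic part of the shared core, and in this assay compound 2 gives 7810 nM. Among the compounds with values here, the single measured step, a 2.2-fold lower number from compound 1 to compound 2 (0.33 log units; beyond the scatter), is therefore the only guide available, and on it compound 2 stands with the lowest of the two numbers, compound 1 being the nearest at the higher figure.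

Compound 3, `COc1ccc2nc(NC(=O)c3cn(-c4ccccc4)nc3-c3ccccc3)sc2c1`, is not yet measured. Relative to compound 2 it shows (methoxy in place of chloro on an aromatic carbon). Within the data shown here, no measured step covers methoxy in place of chloro, so the step from compound 1 to compound 2 bears on it only in that it concerns the same aromatic carbon; it shows that substitution there moved the number modestly downward. Compound 3 is expected to land near compound 2, with a step of a 1.3-fold higher number from compound 2 to compound 3 (0.11 log units; within the scatter) that may not exceed the scatter, and its estimated value is 10000 nM, between 4000 nM and 25000 nM.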

Compound 3, half-maximal inhibitory concentration: > 50000 nM
Compound 3 was reported as a limit; the forecaster's own chance of this, stated with the estimate: 5%; middle value at least 5.0-fold (0.69 log units) away from the limit.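

In this assay, compound 3 gives > 50000 nM, which is a limit of the assay and not a number. Within the data shown here, at this aromatic carbon, methoxy in place of chloro gives an at least 6.4-fold higher number from compound 2 to compound 3 (0.80 log units; beyond the scatter), and methoxy in place of hydrogen gives an at least 2.9-fold higher number from compound 1 to compound 3 (0.47 log units; beyond the scatter), so the direction of the change depends on the group placed there: chloro lowered the number from that of the unsubstituted compound, whereas methoxy raises it, a reversal that the single earlier step could not reveal. Both new steps have a lower bound only, so their full size stays unknown, and the upward direction rests on a single compound at the limit: the limit of > 50000 nM in this assay, at which 1 of the 3 values shown sits.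

The compounds shown leave open which part of the methoxy group goes with the higher number, a question that a hydroxy group or a methyl group at the same aromatic carbon would address. They also leave open whether fluoro or bromo would follow chloro, and whether an amine or a carboxylic acid there would keep the number low or push it to the same limit.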